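The source may hold more compounds than are shown below. What is called first, only, known or untested is meant among the compounds shown, and "the series" means these compounds.

Series notes. Within the data shown here, compound 1 `CCN1CCc2c(sc(NC(=O)Nc3ccc(Cl)cc3)c2C(N)=O)C1` in a functional assay (strain AB) with Danio rerio as the target, read by microscopy, with a stated time of 1 h (a lower number here means that less compound is needed, a higher number that more compound is needed for the effect), gives 3120 nM, which puts compound 1 second highest of the three numbers measured so far. Compound 2 `CN1CCc2c(sc(NC(=O)Nc3ccc(Cl)cc3)c2C(N)=O)C1` gives 4700 nM, and the step of a 1.5-fold higher number from compound 1 to compound 2 (0.18 log units; within the scatter) changes nothing that the scatter would not cover. Compound 3 `CC(C)(C)OC(=O)CCCCN1CCc2c(sc(NC(=O)Nc3ccc(Cl)cc3)c2C(N)=O)C1` gives 710 nM; here a 4.4-fold lower number from compound 1 to compound 3 (0.64 log units; beyond the scatter) and a 6.6-fold lower number from compound 2 to compound 3 (0.82 log units; beyond the scatter) are modest but beyond the scatter.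

Compound 4 `CCN1CCc2c(sc(NC(=O)Nc3ccc(Cl)cc3)c2C(=O)OC)C1` differs from compound 1 by methoxy in place of amino on a carbonyl carbon, that is, carbamoyl to methoxycarbonyl, on the carbonyl carbon whose other neighbour is an aromatic carbon. None of the three measured steps bears on this position: all of them alter the substituent on the amine nitrogen in the ring and leave the carbonyl group of the shared core unchanged. Among the measured compounds shown here, there is therefore no measured step from which the size or direction of the move to compound 4 could be read, and the expectation rests on compound 1 alone, with a range wide enough to allow a change beyond the scatter in either direction.

For compound 4 the number expected in this assay is 4500 nM, within 1200 nM to 18000 nM, which means an expected step of a 1.4-fold higher number from compound 1 to compound 4 (0.16 log units; within the scatter).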

Compound 4, half-maximal effective concentration: > 25000 nM
Compound 4 gave a limit, no number (the forecaster's own chance of this, stated with the estimate: 10%); at least 5.5-fold (0.74 log units) between middle value and limit.
By their numbers in this assay, from the lowest: compound 3; then compounds 1 and 2 (each within the scatter of the next). At a limit, above all of these: compound 4.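

In this assay, methoxy in place of amino on a carbonyl carbon, that is, carbamoyl to methoxycarbonyl, gives an at least 8.0-fold higher number from compound 1 to compound 4 (0.90 log units; beyond the scatter). Compound 4 gives a limit of the assay, not a number: the limit of > 25000 nM in this assay, at which 1 of the 4 values shown sits. This is the first change shown away from the amine nitrogen in the ring and the only step in the series to a higher number beyond the scatter, so the carbamoyl group on the shared core cannot be exchanged for methoxycarbonyl without a clear loss in this assay, while the full size of that loss stays unknown.

The compounds shown leave open whether the amino group as such or its hydrogen-bond donor is what counts, and a methylamino or dimethylamino group or a carboxylic acid on the same carbonyl carbon would bear on that question. Also open, on these data alone, is whether the 3-(tert-butoxycarbonyl)propyl group of compound 3, on the amine nitrogen in the ring, would recover any of the effect when combined with methoxycarbonyl.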